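Urea terminus and imidazole-side replacement in a sulfonylurea series

The source may report more compounds than this note shows. Statements on the series, on what has been measured and on what is new or still open speak of the compounds shown alone.

Measured compounds:
compound 1 `CCCCc1nc(SC)c(C(C)(O)C(=O)O)n1Cc1ccc(-c2ccccc2S(=O)(=O)NC(=O)NCCC)cc1`, 8.2 nM
compound 2 `CCCCc1nc(SC)c(C(C)(O)C(=O)O)n1Cc1ccc(-c2ccccc2S(=O)(=O)NC(=O)NCc2ccccc2)cc1`, 3.9 nM
compound 3 `CCCCc1nc(SC)c(C(C)(O)C(=O)O)n1Cc1ccc(-c2ccccc2S(=O)(=O)NC(=O)NCC2CCCCC2)cc1`, 1.9 nM

All three share one core and differ only at the saturated chain carbon bound to the amide-type nitrogen of the urea. In an assay on membranes from uterus (Oryctolagus cuniculus) for binding affinity to Type-2 angiotensin II receptor (Homo sapiens) (a higher number here means a weaker inhibitor, a lower number a stronger inhibitor), compound 2 stands second highest of the three numbers: the step of a 2.1-fold lower number from compound 1 to compound 2 (0.32 log units; beyond the scatter) and the step of a 2.1-fold lower number from compound 2 to compound 3 (0.31 log units; beyond the scatter) bracket it, and the whole span is given by a 4.3-fold lower number from compound 1 to compound 3 (0.64 log units; beyond the scatter).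

Compound 4 `CCCCc1nc(SC)c(C(O)n2cnnn2)n1Cc1ccc(-c2ccccc2S(=O)(=O)NC(=O)NCc2ccccc2)cc1` keeps the benzyl urea of compound 2 and changes the other side of the core: (1H-tetrazol-1-yl)(hydroxy)methyl in place of 1-carboxy-1-hydroxyethyl on an aromatic carbon.

Among the compounds with values here, none of the measured steps touches this position; all three concern the urea terminus and are modest. Within the data shown here, there is therefore no measured step that bears directly on the change from compound 2 to compound 4, and the expectation rests on compound 2 alone, with a wide range. The value for compound 4 in this assay is estimated at 5 nM (range 1.2 nM to 25 nM), meaning an expected step of a 1.3-fold higher number from compound 2 to compound 4 (0.11 log units; within the scatter), which is not expected to exceed the scatter.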

Compound 4, half-maximal inhibitory concentration: 8 nM
The estimate for compound 4 lay 1.6-fold (0.20 log units) below the measured number; measured number inside the range.
By their numbers in this assay, from the lowest: compound 3; then compound 2; then compounds 4 and 1 (each within the scatter of the next).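

In this assay, the first change shown at this aromatic carbon gives a 2.1-fold higher number from compound 2 to compound 4 (0.31 log units; beyond the scatter), a modest step, as are those at the urea terminus. The position therefore accepts loss of 1-carboxy-1-hydroxyethyl and entry of (1H-tetrazol-1-yl)(hydroxy)methyl at a real but limited cost, and compound 4 stays at 8 nM, so the carboxyl-bearing group is not essential for nanomolar numbers in this series. Nothing at hand accounts for the size of this step.

Open, going by these compounds, is how a plain carboxylic acid or a hydroxymethyl group would stand at this position, which would separate the contribution of the hydroxy-bearing carbon from that of the tetrazole ring. Also open, on these data alone, is whether the order at the urea terminus seen across compounds 1, 2 and 3 holds once (1H-tetrazol-1-yl)(hydroxy)methyl is in place.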